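The source may report more compounds than this note shows. Statements on the series, on what has been measured and on what is new or still open speak of the compounds shown alone.

Compound 1 `CC(C)(C)C(=O)Nc1ccc(-c2cn([C@@H]3CN[C@H](C(=O)Nc4ccc(Cl)c(C(F)(F)F)c4)C3)nn2)cn1`: 43800 nM
Compound 2 `CS(=O)(=O)Nc1ccc(-c2cn([C@@H]3CN[C@H](C(=O)Nc4ccc(Cl)c(C(F)(F)F)c4)C3)nn2)cn1`: 5060 nM
Compound 3 `CC(=O)Nc1n[nH]c2cc(-c3cn([C@@H]4CN[C@H](C(=O)Nc5ccc(Br)cc5)C4)nn3)ccc12`: 3830 nM

In a functional assay on K562 cells (Homo sapiens) for inhibition, read by MTT assay, with a stated time of 48 h (on this read-out higher numbers stand for weaker inhibition and lower numbers for stronger inhibition), compound 2 gives 5060 nM, which lies within the scatter of compound 3 and clearly under compound 1. Compound 4 `Nc1nc2ccc(-c3cn([C@@H]4CN[C@H](C(=O)Nc5ccc(Cl)c(C(F)(F)F)c5)C4)nn3)nc2s1` keeps the rest of compound 2 but exchanges its 6-(methanesulfonamido)pyridin-3-yl: a group of 10 heavy atoms (6 carbon, 3 nitrogen, 1 sulfur; one five-membered aromatic ring with 2 hetero atoms, one six-membered aromatic ring with 1 hetero atom) in place of a group of 11 heavy atoms (6 carbon, 2 nitrogen, 2 oxygen, 1 sulfur; one six-membered aromatic ring with 1 hetero atom), on an aromatic carbon. Within the data shown here, the only measured step that bears on this is an 8.7-fold lower number from compound 1 to compound 2 (0.94 log units; beyond the scatter), a modest change, yet beyond the scatter, made within that same group. That step shows this part of the molecule can move the number, but it gives no direction for replacing the whole group. No clear change is therefore expected in this assay. The expected step, a 1.2-fold higher number from compound 2 to compound 4 (0.07 log units; within the scatter), is an estimate that stays within the scatter. Compound 4 is expected to give about 6000 nM, with an estimated range of 1800 nM to 25000 nM.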

Compound 4, half-maximal inhibitory concentration: 26200 nM
Compound 4: the middle estimate sits 4.4-fold (0.64 log units) below what was measured; the measured number lies above the stated range.
By their numbers in this assay, from the lowest: compounds 3 and 2 (each within the scatter of the next); then compounds 4 and 1 (each within the scatter of the next).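

In this assay, replacing the whole 6-(methanesulfonamido)pyridin-3-yl with the group holding a five-membered and a six-membered aromatic ring gives a 5.2-fold higher number from compound 2 to compound 4 (0.71 log units; beyond the scatter) and so weakens inhibition. The earlier step changed only the group on the nitrogen, whereas this one shows that exchanging the entire group on this aromatic carbon also moves the number beyond the scatter, here upward. No measurement here accounts for this rise.

The compounds shown leave open how a simple amine or a carboxylic acid would compare on this same aromatic carbon.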